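This account rests on a few compounds, and the source may have more. Where it says the series, first, only, none or still open, it means among the compounds named here.

For the measured compounds named here, in a functional assay on A549 cells (Homo sapiens) for inhibition, read by MTT assay, with a stated time of 72 h (on this read-out higher numbers stand for weaker inhibition and lower numbers for stronger inhibition), compound 2 `CC1=NN(c2ccccc2)C(=O)[C@]12C(=O)C=CC[C@H]2c1ccc(C)cc1` gives 2890 nM, the lower of the two numbers so far, while compound 1 `CC1=NN(c2ccccc2)C(=O)[C@]12C(=O)C=CC[C@H]2c1ccccc1[N+](=O)[O-]` gives 12900 nM. Compound 3 `CC1=NN(c2ccccc2)C(=O)[C@]12C(=O)C=CC[C@@H]2c1ccc(C)cc1` keeps the atoms and bonds of compound 2: the two compounds have the same atoms and bonds and differ only in configuration as drawn: 1 of 2 stereo elements differ; a stereocentre at a saturated ring carbon is drawn S in compound 2 and R in compound 3. A stereocentre at a saturated ring carbon is drawn S in compound 2 and R in compound 3. Going by the values given here, the only measured step, a 4.5-fold lower number from compound 1 to compound 2 (0.65 log units; beyond the scatter), swaps a group rather than a configuration, so it bears only loosely and sets a rough scale. A smaller step towards a higher number is expected, perhaps none beyond the scatter. The expected step is a 1.7-fold higher number from compound 2 to compound 3 (0.24 log units; within the scatter). For compound 3 the estimate is 5000 nM, with an expected range of 1500 nM to 15000 nM.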

Compound 3, half-maximal inhibitory concentration: 8600 nM
Estimate against measurement, compound 3: 1.7-fold (0.24 log units) below; low and high end bracket the measured number.
By their numbers in this assay, from the lowest: compound 2; then compounds 3 and 1 (each within the scatter of the next).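

At this saturated ring carbon, configuration alone registers in this assay, with a 3.0-fold higher number from compound 2 to compound 3 (0.47 log units; beyond the scatter). The earlier step swapped a group, whereas here 4-methylphenyl stays in place and the carbon drawn S carries the lower number. The step can be assigned to this stereocentre alone because of one fact: the fact that compounds 2 and 3 differ only in the configuration as drawn

Open, going by these compounds, is whether the same configuration step holds with 2-nitrophenyl on this carbon, and what the second stereo element contributes. Also open, on these data alone, is how a phenyl bearing an amine or a carboxylic acid would read here in either configuration.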